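This account rests on a few compounds, and the source may have more. Where it says the series, first, only, none or still open, it means among the compounds named here.

Of the compounds shown here, two built on a shared core have been measured in an assay on CHO cells for displacement of a labelled ligand from melanin-concentrating hormone receptor 1 (Homo sapiens), read by scintillation counting, with a stated time of 1 h; a higher number here means a weaker inhibitor, a lower number a stronger inhibitor. Compound 1 `Cc1c(C2CC2)nc2ccc(-n3ccc(OCc4ccc(Br)cc4)cc3=O)cn12` gives 12 nM in this assay, and compound 2 `Cc1c(C2CC2)nc2ccc(-n3ccc(OCc4ccccn4)cc3=O)cn12` gives 240 nM. For the measured compounds named here, compound 2 thus stands with the highest of the two numbers, and the only measured step, a 20-fold higher number from compound 1 to compound 2 (1.30 log units; beyond the scatter), shows that exchanging the group on a saturated chain carbon bound to an oxygen on an aromatic ring can move the number a great deal.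

Compound 3 `Cc1c(C2CC2)nc2ccc(-n3ccc(OCc4csc(C(F)(F)F)c4)cc3=O)cn12` has not been measured; it differs from compound 2 by 5-(trifluoromethyl)thiophen-3-yl in place of pyridin-2-yl on a saturated chain carbon bound to an oxygen on an aromatic ring. Going by the values given here, that measured step is the only one bearing on this change, and it was large; it ran from a ring without a ring nitrogen, carrying a halogen, to a ring with a ring nitrogen. Compound 3 again brings in a ring without a ring nitrogen, carrying halogen atoms. For compound 3 a step back toward the lower number is therefore expected, an 8.0-fold lower number from compound 2 to compound 3 (0.90 log units; beyond the scatter). Compound 3 is estimated at 30 nM in this assay, with a range from 8 nM to 120 nM.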

Compound 3, half-maximal inhibitory concentration: 17 nM
Compound 3: middle estimate off by 1.8-fold (0.25 log units), on the high side; low and high end bracket the measured number.
By their numbers in this assay, from the lowest: compounds 1 and 3 (each within the scatter of the next); then compound 2.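

In this assay, the place on a saturated chain carbon bound to an oxygen on an aromatic ring now shows a second large step, a 14-fold lower number from compound 2 to compound 3 (1.15 log units; beyond the scatter), so a low number here is not tied to 4-bromophenyl alone. Two quite different groups, the five-membered 5-(trifluoromethyl)thiophen-3-yl and the six-membered 4-bromophenyl, cannot be told apart in this assay, a 1.4-fold higher number from compound 1 to compound 3 (0.15 log units; within the scatter), which leaves pyridin-2-yl in compound 2 alone at the high number among these three compounds. No measurement at hand gives a reason for these differences.

The compounds shown leave open whether the ring nitrogen of pyridin-2-yl goes with the higher number, or whether the missing halogen atoms do. A plain phenyl ring and a pyridine ring carrying a trifluoromethyl group would help separate these two readings.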